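Swapping 1H-indol-4-yl for 1H-indazol-5-yl in compound 2

The compounds below may be only part of what the source reports. "The series", "measured", "known", "first", "only" and "open" are said of these compounds alone.

Compound 1 `Cn1c(=O)c(S(=O)(=O)c2ccc(C(=O)O)cc2)cc2cnc(Nc3ccc4[nH]ccc4c3)nc21` gives 5000 nM
Compound 2 `Cn1c(=O)c(S(=O)(=O)c2ccc(F)cc2F)cc2cnc(Nc3cccc4[nH]ccc34)nc21` gives 1500 nM
Compound 3 `COc1ccc(S(=O)(=O)c2cc3cnc(Nc4ccc5[nH]ccc5c4)nc3n(C)c2=O)cc1` gives 300 nM

In a functional assay on K562 cells (Homo sapiens) for inhibition, read by trypan blue exclusion, with a stated time of 72 h (a higher number here means a weaker inhibitor, a lower number a stronger inhibitor), compound 2 (1500 nM) sits in the middle of the three measured numbers, with compound 1 higher and compound 3 lower, and both gaps lie beyond the scatter. Compound 4 `Cn1c(=O)c(S(=O)(=O)c2ccc(F)cc2F)cc2cnc(Nc3ccc4[nH]ncc4c3)nc21` differs from compound 2 in one group only, 1H-indazol-5-yl in place of 1H-indol-4-yl on a nitrogen on an aromatic ring.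

Going by the values given here, the only measured step (a 17-fold lower number from compound 1 to compound 3 (1.22 log units; beyond the scatter)) is large, but it is methoxy in place of carboxy on an aromatic carbon, a change elsewhere on the molecule, so it does not test this swap directly. Compound 3 (300 nM) shows a lower number than compound 2, yet the two differ in more than one place, so that gap cannot be credited to a single group. Among the compounds with values here, no measured pair isolates the swap, so only a small move to a lower number in this assay is expected, one that may stay within the scatter. The estimated change is a 1.9-fold lower number from compound 2 to compound 4 (0.27 log units; within the scatter) as a rough guess. For compound 4 the estimated value is 800 nM and the expected range runs from 200 nM to 3000 nM on this thin evidence.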

Compound 4, half-maximal inhibitory concentration: 50000 nM
Compound 4: the middle estimate sits 63-fold (1.80 log units) below what was measured, outside the stated range (above it).
By their numbers in this assay, from the lowest: compound 3; then compound 2; then compound 1; then compound 4.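

Going by these compounds alone, the swap is the first direct test of the group on this nitrogen, and in this assay it brings a 33-fold higher number from compound 2 to compound 4 (1.52 log units; beyond the scatter), so this place is highly sensitive to what it carries even though the rest of the molecule stays the same. The two groups are closely matched in the counts, with 9 heavy atoms and 1 hydrogen-bond donor each, yet 1H-indazol-5-yl has 2 nitrogen atoms where 1H-indol-4-yl has 1, brings 1 hydrogen-bond acceptor where the other has 0, and is joined through a different ring position, as the numbers in the names show. No measurement at hand explains why this change costs so much.

Because the ring atoms and the point of attachment change together, the compounds shown cannot tell which of the two matters, and a 1H-indazol-4-yl group on the rest of compound 2 would help to separate them. As far as these compounds go, it also remains open whether the same swap would have a similar effect alongside the methoxy or carboxy groups of compound 3 and compound 1.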